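The source may hold more compounds than are shown below. What is called first, only, known or untested is meant among the compounds shown, and "the series" means these compounds.

Measured compounds in a functional assay on HeLa cells (Homo sapiens) for cytotoxicity, read by MTT assay, with a stated time of 48 h; on this read-out lower numbers stand for stronger inhibition and higher numbers for weaker inhibition:
compound 1 `COc1ccc(N/C(CCNC2=CC(=O)c3ccccc3C2=O)=N\S(=O)(=O)c2ccc(C)cc2)cc1`: 7590 nM
compound 2 `Cc1ccc(S(=O)(=O)/N=C(/CCNC2=CC(=O)c3ccccc3C2=O)Nc2ccccc2I)cc1`: 19100 nM
compound 3 `Cc1ccc(S(=O)(=O)/N=C(/CCNC2=CC(=O)c3ccccc3C2=O)Nc2ccc(F)c(F)c2)cc1`: 8790 nM

Compound 3 stands second highest of the three numbers in this assay. Its nearest neighbour is compound 1, a step of a 1.2-fold higher number from compound 1 to compound 3 (0.06 log units; within the scatter) that is within the scatter, so the two are not told apart. Compound 2 lies furthest away, the step of a 2.2-fold lower number from compound 2 to compound 3 (0.34 log units; beyond the scatter) being beyond the scatter but still modest. The third measured step, a 2.5-fold higher number from compound 1 to compound 2 (0.40 log units; beyond the scatter), is of the same modest kind.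

Compound 4 `Cc1ccc(S(=O)(=O)/N=C(/CCNC2=CC(=O)c3ccccc3C2=O)NC2CCCCC2)cc1` is not yet measured. The change from compound 3 is cyclohexyl in place of 3,4-difluorophenyl on an amine nitrogen. All three measured steps exchange one aromatic ring for another at the same amine nitrogen, and none of them replaces the aromatic ring by a non-aromatic one, so they bear on the step only indirectly. They show that swaps at this position move the number by modest amounts at most. A step of similar size is therefore expected for a 1.4-fold higher number from compound 3 to compound 4 (0.14 log units; within the scatter), with the direction uncertain and a slightly higher number held somewhat more likely. Compound 4 is thus estimated at 12000 nM in this assay, within a range from 5000 nM to 30000 nM.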

Compound 4, half-maximal inhibitory concentration: 9770 nM
Beside the measured number, compound 4's estimate is 1.2-fold (0.09 log units) above it; low and high end bracket the measured number.
By their numbers in this assay, from the lowest: compounds 1, 3, 4 and 2 (each within the scatter of the next, the first and the last beyond it).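

In this assay, a non-aromatic ring on this amine nitrogen gives a number that cannot be told apart from those of the aromatic rings: a 1.1-fold higher number from compound 3 to compound 4 (0.05 log units; within the scatter), and a 1.3-fold higher number from compound 1 to compound 4 (0.11 log units; within the scatter). Even against 2-iodophenyl, the one group here that differs beyond the scatter from the other aromatic rings, a 2.0-fold lower number from compound 2 to compound 4 (0.29 log units; within the scatter). Among these four compounds, then, an aromatic ring at this position is not needed for a number of this size, and no evidence at hand bears on the reason.

Open, from the compounds shown here alone, is whether something other than a six-membered carbon ring on this nitrogen, such as a short alkyl chain or a ring carrying a carboxylic acid, would move the number further. Also open, going by these compounds, is how changes to the rest of the shared core, constant in all four compounds, compare with changes at this position.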